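Series notes: five-membered ring variation on the shared core

The source may report more compounds than this note shows. Statements on the series, on what has been measured and on what is new or still open speak of the compounds shown alone.

Measured so far in an assay on CHO cells for displacement of a labelled ligand from prostaglandin E2 receptor EP3 subtype (Homo sapiens), read by radioligand binding; on this read-out higher numbers stand for weaker inhibition and lower numbers for stronger inhibition: compound 1 `CC(C)C(c1ncc[nH]1)c1ccc(-c2ccc3cccc(F)c3c2)[nH]c1=O` gives 7.3 nM; compound 2 `CC(C)C(c1ccc(-c2ccc3cccc(F)c3c2)[nH]c1=O)N1CCN/C1=N\C#N` gives 23 nM; compound 3 `CC(C)C(c1noc(=O)[nH]1)c1ccc(-c2ccc3cccc(F)c3c2)[nH]c1=O` gives 15 nM.

Compound 3 stands second highest of the three numbers. Its nearest neighbour lies within the scatter: a 1.5-fold lower number from compound 2 to compound 3 (0.19 log units; within the scatter). The gap to the lowest number is beyond the scatter: a 2.1-fold higher number from compound 1 to compound 3 (0.31 log units; beyond the scatter).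

The next compound, compound 4 `CC(C)C(c1ncco1)c1ccc(-c2ccc3cccc(F)c3c2)[nH]c1=O`, differs from compound 3 in one place: a group of 5 heavy atoms (3 carbon, 1 nitrogen, 1 oxygen; one five-membered aromatic ring with 2 hetero atoms) in place of a group of 6 heavy atoms (2 carbon, 2 nitrogen, 2 oxygen; one five-membered aromatic ring with 3 hetero atoms), on a saturated chain carbon bound to an aromatic carbon and a saturated chain carbon. Within the data shown here, two measured steps bear on this change, both replacing the ring of compound 1 with a larger group: a 2.1-fold higher number from compound 1 to compound 3 (0.31 log units; beyond the scatter) and a 3.2-fold higher number from compound 1 to compound 2 (0.50 log units; beyond the scatter). Both gave modest higher numbers. Among the measured compounds shown here, compound 4 returns to a five-membered aromatic ring with 2 hetero atoms, like compound 1, but the 1,3-oxazol-2-yl group carries 0 hydrogen-bond donors where the leaving group carries 1, and no compound measured here separates those two features. The expectation is therefore a small step toward the number of compound 1, not clearly beyond the scatter: a 1.3-fold lower number from compound 3 to compound 4 (0.10 log units; within the scatter) is expected. For compound 4 the estimate in this assay is 12 nM, with a range from 4 nM to 40 nM.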

Compound 4, inhibition constant: 24 nM
Beside the measured number, compound 4's estimate is 2.0-fold (0.30 log units) below it; the range from low to high includes it.
By their numbers in this assay, from the lowest: compound 1; then compounds 3, 2 and 4 (each within the scatter of the next).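

In this assay, 1,3-oxazol-2-yl in place of 1H-imidazol-2-yl gives a 3.3-fold higher number from compound 1 to compound 4 (0.52 log units; beyond the scatter). Among these compounds, this is the first step at this position in which the entering group keeps the 5 heavy atoms and the five-membered aromatic ring with 2 hetero atoms, so a higher number here does not require a larger group or a change of ring size. The other two steps, a 1.6-fold higher number from compound 3 to compound 4 (0.20 log units; within the scatter) and a 1.0-fold higher number from compound 2 to compound 4 (0.02 log units; within the scatter), lie within the scatter, so compound 2, compound 3 and compound 4 cannot be told apart despite their different rings, and among the four groups on the saturated chain carbon only the 1H-imidazol-2-yl of compound 1 stands apart. Nothing available here offers an explanation for any of these steps.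

On these data alone, it remains open whether the number of compound 1 depends on the ring hydrogen on nitrogen of 1H-imidazol-2-yl, which a 1-methylimidazol-2-yl or a 1,3-thiazol-2-yl group at the same place would help to test. The compounds shown also leave open how an open-chain group, such as a carboxylic acid or a primary amine, would compare with these rings on that carbon.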